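A few compounds are considered here, and "the series" means these few. Any claim that something is new, unique, unknown or untested is made for them only; others in the source may bear on it.

Measured so far:
compound 1 `CNCc1cc(-c2cccnc2C#N)n(S(=O)(=O)c2ccccc2)c1`: 99%
compound 2 `CNCc1cc(-c2cccnc2F)n(S(=O)(=O)c2ccco2)c1`: 74%
compound 3 `CNCc1cc(-c2cccnc2C#N)n(S(=O)(=O)c2cccnc2)c1`: 48%

In a functional assay on the whole organism (strain Jcl:SD) for inhibition, with Rattus norvegicus as the target, with stated times of 3 min and 3 h, at a dose of 1 mg/kg by the intravenous route (a lower number here means less inhibition, a higher number more inhibition at the dose given (going by the name of the read-out)), compound 3 gives 48%, the lowest of the three numbers; compound 2 gives 74% and compound 1 gives 99%. Among the compounds with values here, the one step measured in a single place, a number 51 percentage points lower from compound 1 to compound 3 (beyond the scatter), concerns the group on the sulfonyl sulfur and so does not bear on the change to compound 4 `CNCc1cc(-c2ccncc2F)n(S(=O)(=O)c2cccnc2)c1`, which is 3-fluoropyridin-4-yl in place of 2-cyanopyridin-3-yl on an aromatic carbon. Compound 1 and compound 2 differ from each other in two places, so their values only show that both lie above compound 3. Within the data shown here, no measured step covers the change on the aromatic carbon, and the expectation is therefore no step beyond the scatter, a number 3 percentage points lower from compound 3 to compound 4 (within the scatter). Compound 4 is expected at 45%, within 15% to 75%.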

Compound 4, a percentage reported as inhibition, in the whole organism at one dose (the size of the read-out at that dose, not a potency) in the Rattus norvegicus assay: 48%
Compound 4: the middle estimate sits 3 percentage points below what was measured; the range from low to high includes it.
By their numbers in the Rattus norvegicus assay, from the lowest: compounds 3 and 4 (each within the scatter of the next); then compound 2; then compound 1.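

At this position on an aromatic carbon, 3-fluoropyridin-4-yl in place of 2-cyanopyridin-3-yl gives, in the Rattus norvegicus assay, no change at the digits printed from compound 3 to compound 4 (within the scatter). In a physicochemical assay for lipophilicity, read by HPLC, at pH 7.4 (on this read-out higher numbers stand for higher lipophilicity and lower numbers for lower lipophilicity), compound 3 gives -1.29 and compound 4 gives -0.34, so lipophilicity can differ at this position while the two inhibition numbers lie within the scatter of each other: the measured distribution coefficient of compound 3, -1.29, and of compound 4, -0.34, a number 0.95 log units higher (beyond the scatter)

The nitrile, the fluorine and the place of the ring nitrogen all differ at once, so their separate contributions cannot be told apart. Open too, from the compounds shown here alone, is how the Rattus norvegicus assay responds to a pyridine bearing an amine or a carboxylic acid at this carbon.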